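Trimethoxyphenyl pyrazole chalcones: removing one methoxy group

The source may report more compounds than this note shows. Statements on the series, on what has been measured and on what is new or still open speak of the compounds shown alone.

Measured compounds in a functional assay on SN12C cells (Homo sapiens) for inhibition, read by sulforhodamine B assay, with a stated time of 48 h; on this read-out higher numbers stand for weaker inhibition of growth and lower numbers for stronger inhibition of growth:
- compound 1, `COc1cc(-c2cc(/C=C/C(=O)c3ccc(N)cc3)[nH]n2)cc(OC)c1OC`: 1860 nM
- compound 2, `COc1cc(-c2cc(/C=C/C(=O)c3ccc(Cl)c(Cl)c3)[nH]n2)cc(OC)c1OC`: 13700 nM
- compound 3, `COc1ccc(C(=O)/C=C/c2cc(-c3cc(OC)c(OC)c(OC)c3)n[nH]2)cc1OC`: 1540 nM

Compound 3 gives the lowest number of the three in this assay. Its nearest neighbour is compound 1, since a 1.2-fold lower number from compound 1 to compound 3 (0.08 log units; within the scatter) lies within the scatter; its furthest is compound 2, since an 8.9-fold lower number from compound 2 to compound 3 (0.95 log units; beyond the scatter) lies beyond it. The other measured step, a 7.4-fold higher number from compound 1 to compound 2 (0.87 log units; beyond the scatter), separates the same two outer compounds.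

Compound 4, `COc1ccc(C(=O)/C=C/c2cc(-c3cc(OC)c(OC)c(OC)c3)n[nH]2)cc1`, differs from compound 3 by hydrogen in place of methoxy on an aromatic carbon. Among the compounds with values here, none of the measured steps removes a methoxy group from the aryl ring on the carbonyl carbon; all three exchange that aryl group as a whole. Within the data shown here, the only indirect guidance is that compound 1 and compound 3, two different aryl groups, sit within the scatter of each other, while compound 2 sits far higher. On that basis the expectation for compound 4 in this assay is a number near that of compound 3, so that a 1.4-fold higher number from compound 3 to compound 4 (0.15 log units; within the scatter) is expected to stay within the scatter. The estimate for compound 4 is 2200 nM, with a range from 800 nM to 6000 nM.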

Compound 4, concentration for 50% growth inhibition: 1810 nM
Estimate against measurement, compound 4: 1.2-fold (0.08 log units) above; measured number inside the range.
By their numbers in this assay, from the lowest: compounds 3, 4 and 1 (each within the scatter of the next); then compound 2.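

Taking out one methoxy group, 3,4-dimethoxyphenyl to 4-methoxyphenyl, is the first single-group change at this aryl ring, and in this assay it gives a 1.2-fold higher number from compound 3 to compound 4 (0.07 log units; within the scatter), so the second methoxy group is not needed to stay within the scatter of compound 3. Methoxy in place of amino on the same ring, the first direct comparison of those two groups, gives a 1.0-fold lower number from compound 1 to compound 4 (0.01 log units; within the scatter), whereas the step from the dichlorinated aryl group gives a 7.6-fold lower number from compound 2 to compound 4 (0.88 log units; beyond the scatter) and leaves compound 2 alone at the high end. No supporting evidence bears on why these steps come out as they do.

Still open, on these data alone, is whether the remaining methoxy group can be replaced by hydrogen or by hydroxyl without leaving the scatter. Also open, as far as these compounds go, is whether a single chlorine would stand with compound 2 or with compound 4.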